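The compounds below may be only part of what the source reports. "The series", "measured", "known", "first", "only" and "open" are said of these compounds alone.

Working notes on the series. Two compounds have numbers in an assay on isolated protein for inhibition of protein deacetylase HDAC6 (Homo sapiens), read by fluorescence, with a stated time of 15 min (a higher number here means a weaker inhibitor, a lower number a stronger inhibitor), so far. Compound 1 `O=C(NO)c1ccc(-c2nnc(Cc3cccc4ccccc34)o2)cc1` gives 4100 nM in this assay. Compound 2 `Nc1ccccc1NC(=O)c1ccc(Cc2nnc(Cc3cccc4ccccc34)o2)cc1` gives 8900 nM in this assay, the higher of the two numbers; its nearest neighbour is compound 1, and the gap between the two lies beyond the usual scatter. Compounds 1 and 2 differ in more than one place, so their two values can only be set side by side, not read as a single step.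

Compound 3 `O=C(NO)c1ccc(Cc2nnc(Cc3cccc4ccccc34)o2)cc1` is not yet measured in this assay. It differs from compound 2 in one place: hydroxy in place of 2-aminophenyl on an amide-type nitrogen. Compound 1 already carries the hydroxycarbamoyl group, on a different core from compound 2, and its number in this assay is lower than that of compound 2. On that basis a step to a lower number, beyond the scatter, is expected from compound 2 to compound 3, of about a 5.9-fold lower number from compound 2 to compound 3 (0.77 log units; beyond the scatter). For compound 3 the estimated value in this assay is 1500 nM, with a range from 300 nM to 6000 nM.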

Compound 3, half-maximal inhibitory concentration: 1200 nM
For compound 3 the middle estimate is 1.3-fold (0.10 log units) above the measured one; the range from low to high includes it.
By their numbers in this assay, from the lowest: compound 3; then compound 1; then compound 2.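

In this assay the change reads a 7.4-fold lower number from compound 2 to compound 3 (0.87 log units; beyond the scatter) with hydroxy in place of 2-aminophenyl on an amide-type nitrogen, and the rest of the structure stays the same. Among the compounds shown here, this is the first reading of this position: compound 1 and compound 2 differ in more than one place, so their values could not separate the effect of the group from that of the core, whereas this pair ties the lower number to this one change. The reading rests on a single pair, and no measurement shown bears on why the number falls.

Open, as far as these compounds go, is how other groups compare on the same amide-type nitrogen of the shared core, such as methoxy or an amine in place of hydroxy, and how a carboxylic acid compares with the whole hydroxycarbamoyl group. For the compounds shown here, also open is whether the same change gives a step of similar size on another core, since the series holds only this one pair for it.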